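Extending an Alkyne with a Second Ring

A few compounds are considered here, and "the series" means these few. Any claim that something is new, unique, unknown or untested is made for them only; others in the source may bear on it.

Measured compounds:
- compound 1 `C#Cc1ccc2ncn(-c3ccnc(N)n3)c2c1` gives 251 nM
- compound 2 `C#Cc1cc(C#Cc2ccc3ncn(-c4ccnc(N)n4)c3c2)ccn1` gives 31600 nM
- compound 3 `C#Cc1nccc(C#Cc2ccc3ncn(-c4ccnc(N)n4)c3c2)n1` gives 39800 nM

All three were tested in an assay on Sf9 cells for inhibition of mitogen-activated protein kinase kinase kinase 14 variant S549D (Homo sapiens), with a stated time of 30 min, in the presence of a further agent that is not named here; on this read-out higher numbers stand for weaker inhibition and lower numbers for stronger inhibition. Among them compound 1 gives the lowest number, the strongest inhibition of the three, and the other two lie far from it.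

Compound 4 `C#Cc1ncc(C#Cc2ccc3ncn(-c4ccnc(N)n4)c3c2)cn1` is built from compound 1 by this change: a group of 8 heavy atoms (6 carbon, 2 nitrogen; one six-membered aromatic ring with 2 hetero atoms) in place of a hydrogen atom, on a triple-bonded carbon

Within the data shown here, two measured steps bear directly on this change, since each also caps the same triple-bonded carbon with a six-membered aromatic ring carrying one or two nitrogen atoms: a 130-fold higher number from compound 1 to compound 2 (2.10 log units; beyond the scatter) and a 160-fold higher number from compound 1 to compound 3 (2.20 log units; beyond the scatter). Both steps are large and point the same way, towards weaker inhibition. Compound 2 and compound 3 differ only in the count and placement of ring nitrogen atoms, and the step between them is small: a 1.3-fold higher number from compound 2 to compound 3 (0.10 log units; within the scatter). Compound 4 carries a ring with the same count of nitrogen atoms as compound 3, placed differently, so a similar large loss is expected, a 140-fold higher number from compound 1 to compound 4 (2.14 log units; beyond the scatter). Compound 4 is therefore estimated at 35000 nM, within the range 12000 nM to 100000 nM.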

Compound 4, half-maximal inhibitory concentration: 79400 nM
For compound 4 the middle estimate is 2.3-fold (0.36 log units) below the measured one; the range from low to high includes it.
By their numbers in this assay, from the lowest: compound 1; then compounds 2, 3 and 4 (each within the scatter of the next, the first and the last beyond it).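

Compound 4 shows that a third arrangement of the added ring brings the same kind of large loss in this assay (a 320-fold higher number from compound 1 to compound 4 (2.50 log units; beyond the scatter)). Moving the two ring nitrogen atoms leaves compound 3 and compound 4 within the scatter of each other (a 2.0-fold higher number from compound 3 to compound 4 (0.30 log units; within the scatter)), while the gap to the ring with one nitrogen atom is only modest (a 2.5-fold higher number from compound 2 to compound 4 (0.40 log units; beyond the scatter)), so in all three compounds the large loss comes with the added group, and the ring nitrogen pattern matters far less. Nothing available here explains this loss.

Going by these compounds, it remains open whether a much smaller group on the same triple-bonded carbon, such as methyl or hydroxymethyl, would keep the inhibition of compound 1. On these data alone, the effect of a plain phenyl ring, with no ring nitrogen and no further triple bond, also stays unknown.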